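The compounds below may be only part of what the source reports. "The series", "measured", "known", "first", "only" and "open" are said of these compounds alone.

Measured compounds in an ADME assay on PC-3 cells (Homo sapiens) for cytotoxicity, read by WST assay, tested at 100 uM; on this read-out higher numbers stand for more inhibition at the one concentration tested (going by the name of the read-out) and lower numbers for less inhibition:
- compound 1, `O=C(Nc1cccc(CN2CCCC2)c1)C1CCCN(C(=O)c2cc(C(F)(F)F)cc(C(F)(F)F)c2)C1`, gives 51%
- compound 2, `O=C(Nc1ccc(Cl)cc1)C1CCCN(C(=O)c2cc(C(F)(F)F)cc(C(F)(F)F)c2)C1`, gives 14%

Going by the values given here, compound 2 stands at the lowest of the two numbers in this assay; the nearest is compound 1, and the single measured step, a number 37 percentage points lower from compound 1 to compound 2 (beyond the scatter), is large. That step exchanges the whole aryl group on the amide-type nitrogen, so it bears only loosely on the next change.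

Compound 3, `O=C(Nc1ccc(Cl)nc1)C1CCCN(C(=O)c2cc(C(F)(F)F)cc(C(F)(F)F)c2)C1`, keeps the core of compound 2 and differs by 6-chloropyridin-3-yl in place of 4-chlorophenyl on an amide-type nitrogen. Among the compounds with values here, the chlorine stays and one ring carbon becomes a nitrogen; no measured pair tests such a change, so the measured step gives no direction for it. In this assay a step from compound 2 to compound 3 of no size beyond the scatter is therefore expected, with the estimated step being a number 1 percentage points higher from compound 2 to compound 3 (within the scatter). Compound 3 is expected to give 15%, within a range of 0% to 35%.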

Compound 3, a percentage reported as inhibition, at one concentration (the size of the read-out at that concentration, not a potency): 25%
For compound 3 the middle estimate is 10 percentage points below the measured one; low and high end bracket the measured number.
By their numbers in this assay, from the lowest: compound 2; then compound 3; then compound 1.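

In this assay this position on the amide-type nitrogen responds to a change of one ring atom while the chlorine stays: 6-chloropyridin-3-yl in place of 4-chlorophenyl gives a number 11 percentage points higher from compound 2 to compound 3 (beyond the scatter). The gain recovers only part of the gap to the aryl group carrying the pyrrolidine, as 6-chloropyridin-3-yl in place of 3-((pyrrolidin-1-yl)methyl)phenyl gives a number 26 percentage points lower from compound 1 to compound 3 (beyond the scatter). No supporting measurement bears on the origin of either step.

Open, going by these compounds, is whether a plain pyridin-3-yl without the chlorine would stay near compound 3, which would show how much the chlorine contributes on this ring. Also open, on these data alone, is whether a pyrrolidin-1-ylmethyl group, another amine or a carboxylic acid in place of that chlorine would carry the number towards compound 1 or away from it.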